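The source may hold more compounds than are shown below. What is called first, only, known or untested is meant among the compounds shown, and "the series" means these compounds.

Of the compounds shown here, three have been measured in a functional assay (Homo sapiens) for inhibition; on this read-out higher numbers stand for weaker inhibition and lower numbers for stronger inhibition. Compound 1, with the structure `C=CCOc1ccc(C(=O)/C=C/c2cc(OC)ccc2OC)cc1`, gives 55000 nM in this assay. Compound 2, with the structure `C=CCOc1ccc(C(=O)/C=C/c2cccc(OC)c2OC)cc1`, gives 96000 nM in this assay. Compound 3, with the structure `COc1cccc(/C=C/C(=O)c2ccc(O)cc2)c1OC`, gives 70000 nM in this assay. All three numbers lie within the usual scatter of one another, so none of them can be called stronger or weaker than the others on this evidence.

Compound 3 is made from compound 2 by one change, (hydrogen in place of allyl on an oxygen on an aromatic ring), and this change brought a 1.4-fold lower number from compound 2 to compound 3 (0.14 log units; within the scatter).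

Compound 4, with the structure `COc1ccc(OC)c(/C=C/C(=O)c2ccc(O)cc2)c1`, has not yet been measured in this assay. It is related to compound 1 by the same change, (hydrogen in place of allyl on an oxygen on an aromatic ring), made at a place described in the same words. Compound 1 and compound 2 share the same atoms joined differently; the difference between the two cores is not broken down here.

Among the measured compounds shown here, because the one measured example of this change gave a 1.4-fold lower number from compound 2 to compound 3 (0.14 log units; within the scatter), a step of similar size, staying within the scatter, is expected from compound 1 to compound 4, namely a 1.2-fold lower number from compound 1 to compound 4 (0.09 log units; within the scatter). Compound 4 is therefore expected to give about 45000 nM in this assay, most likely between 20000 nM and 110000 nM. This rests on a single measured step, so the expectation is loose.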

Compound 4, half-maximal inhibitory concentration: 22000 nM
Beside the measured number, compound 4's estimate is 2.0-fold (0.31 log units) above it, within the range that was stated.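

In this assay, putting hydrogen in place of allyl on the oxygen, which turns allyloxy into hydroxy, brings a 2.5-fold lower number from compound 1 to compound 4 (0.40 log units; beyond the scatter). This is a modest step, but unlike the earlier example it lies beyond the scatter of repeated measurements. Set side by side, the two steps agree as closely as such measurements allow, so on this evidence the change carries over from one core to the other: the same change on two cores in this assay, a 1.4-fold lower number (0.14 log units; within the scatter) from compound 2 to compound 3 and a 2.5-fold lower number (0.40 log units; beyond the scatter) from compound 1 to compound 4, 1.8-fold (0.26 log units) apart, within the scatter of two such steps. Among the compounds shown here, this does not show that the change lowers the number on every core, since only two cores are compared and the step on one of them stays within the scatter, which leaves a real gain supported only on the core of compound 1.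

The compounds shown carry only allyl or hydrogen on this oxygen, so it remains open how a longer chain such as butyl, or a chain ending in an amine or a carboxylic acid, would fare at that place. On these data alone, all four compounds also keep two methoxy groups on their other ring, so what happens when one of these gives way to a fluorine or a nitrile remains open too.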